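The source may hold more compounds than are shown below. What is called first, only, known or untested is meant among the compounds shown, and "the series" means these compounds.

Compound 1 `CCOc1ccc2nc(Nc3nc4ccc(F)cc4s3)sc2c1` is measured in a functional assay on B16-F10 cells (Mus musculus) for cytotoxicity, read by MTT assay, with a stated time of 48 h (a lower number here means a stronger inhibitor, a higher number a weaker inhibitor), where compound 1 gives 33200 nM. Compound 3 `Cc1ccc2nc(Nc3nc4ccc(F)cc4s3)sc2c1` gives 29600 nM in this assay, and the step of a 1.1-fold lower number from compound 1 to compound 3 (0.05 log units; within the scatter) leaves the two within the usual scatter, so the numbers do not separate them. Compound 2 `Fc1ccc2nc(NC(=S)Nc3ccccc3)sc2c1` reaches only a limit, > 50000 nM, which is the limit of > 50000 nM in this assay, at which 1 of the 3 values shown sits. Compound 4 `CCOc1ccc2nc(Nc3nc4ccccc4s3)sc2c1` differs from compound 1 by a single change: hydrogen in place of fluoro on an aromatic carbon. Among the measured compounds shown here, no measured step touches the fluoro on that ring; the only step seen, from ethoxy to methyl, stayed within the scatter. The step is therefore expected to be small, a 1.1-fold higher number from compound 1 to compound 4 (0.02 log units; within the scatter). Compound 4 is estimated at 35000 nM, with a range from 15000 nM to 70000 nM.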

Compound 4, half-maximal inhibitory concentration: > 50000 nM
Compound 4: no number, only a limit (the forecaster's own chance of this, stated with the estimate: 25%); middle value at least 1.4-fold (0.15 log units) away from the limit.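

Hydrogen in place of fluoro is the first change shown at this position, and it gives an at least 1.5-fold higher number from compound 1 to compound 4 (0.17 log units; that floor lies within the scatter). That step is only a floor and it lies within the scatter, so the data do not show that the fluoro matters, though a much larger step is not excluded. In this assay compound 4 gives a limit, not a number: the limit of > 50000 nM in this assay, at which 2 of the 4 values shown sit.

The compounds shown leave open how a chloro, a methoxy or an amine would read in this same place. They also leave open whether removing the fluoro would give a clearer step with methyl in place of ethoxy.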